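The source may hold more compounds than are shown below. What is called first, only, known or untested is meant among the compounds shown, and "the series" means these compounds.

Compound 1 `O=C(/C=C/c1ccccc1)c1ccc[nH]1` gives > 100000 nM in a functional assay on HL-60 cells (Homo sapiens) for inhibition, read by MTT assay, with a stated time of 48 h; on this read-out higher numbers stand for weaker inhibition and lower numbers for stronger inhibition; this is a limit of the assay, not a number.
Compound 2 `O=C(/C=C/c1ccc([N+](=O)[O-])cc1)c1ccc[nH]1` gives 14000 nM in this assay.
Compound 3 `O=C(/C=C/c1cccc([N+](=O)[O-])c1)c1ccc[nH]1` gives 20000 nM in this assay.

All three compounds share the same core, in which a phenyl ring is joined through an unsaturated ketone to a pyrrole. For compound 1 only a limit is known (the limit of > 100000 nM in this assay, at which 1 of the 3 values shown sits), so its true number can only be said to lie at or beyond it. The two measured steps each add a nitro group to the phenyl ring: an at least 7.1-fold lower number from compound 1 to compound 2 (0.85 log units; beyond the scatter) and an at least 5.0-fold lower number from compound 1 to compound 3 (0.69 log units; beyond the scatter). Both steps are beyond the scatter, and both lower the number at least modestly.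

Compound 4 `O=C(/C=C/c1ccccc1Br)c1ccc[nH]1` differs from compound 1 by bromo in place of hydrogen on an aromatic carbon. The measured steps bear on this change only loosely: both replace a hydrogen on the same ring, but with a nitro group rather than bromine, and neither sits at the same place as the bromine in compound 4. Some lowering of the number is therefore expected in this assay, likely smaller than either nitro step, and a limit cannot be ruled out. For compound 4 the expected step is an at least 2.5-fold lower number from compound 1 to compound 4 (0.39 log units; beyond the scatter). Compound 4 is estimated at 40000 nM, with a range from 10000 nM to 150000 nM.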

Compound 4, half-maximal inhibitory concentration: 42000 nM
Compound 4: the middle estimate sits 1.1-fold (0.02 log units) below what was measured; the measured number falls inside the stated range.
By their numbers in this assay, from the lowest: compounds 2 and 3 (each within the scatter of the next); then compound 4. At a limit, above all of these: compound 1.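

The bromo group, sitting ortho to a group of 9 heavy atoms, brings the number down in this assay with an at least 2.3-fold lower number from compound 1 to compound 4 (0.37 log units; beyond the scatter), and this step lies beyond the usual scatter. Until now, only nitro groups had been seen to lower the number from compound 1, and neither of them sat at this place on the ring, so compound 4 shows that a single bromine atom in place of a hydrogen at this position is also enough to produce a measurable number. As far as these compounds go, the step can be given only as a minimum because compound 1 stands at a limit of the assay and has no exact value, which means that the true size of the change remains unknown: the limit of > 100000 nM in this assay, at which 1 of the 4 values shown sits.

The compounds shown do not separate the effect of the group from the effect of its place, as bromo appears at only one position and no nitro group appears at this one. From the compounds shown here alone, it also remains open whether a chloro group, an amine or a carboxylic acid at this same position would lower the number as well.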